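A Methoxyphenyl Ketone Appended to a Triazole Thioether

The compounds below may be only part of what the source reports. "The series", "measured", "known", "first", "only" and "open" are said of these compounds alone.

Compound 1 `C#CCSc1nnc(-c2cc(OC)c(OC)c(OC)c2)n1N1C(=O)c2ccccc2C1=O`: > 200000 nM
Compound 2 `COc1cc(-c2nnc(SC)n2N2C(=O)c3ccccc3C2=O)cc(OC)c1OC`: > 200000 nM

Of the compounds shown here, two have been measured in a functional assay on A549 cells (Homo sapiens) for cytotoxicity, read by MTT assay, with a stated time of 48 h; on this read-out higher numbers stand for weaker inhibition and lower numbers for stronger inhibition. Compound 1 gives > 200000 nM, which is a limit of the assay rather than a number. Compound 2 likewise gives > 200000 nM, also a limit. The step that the two limits leave unreadable from compound 1 to compound 2 is therefore unreadable; both values sit at the limit of > 200000 nM in this assay, at which 2 of the 2 values shown sit. On these numbers compound 2 stands at the limit, and nothing separates it from compound 1.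

Compound 3 `COc1ccc(C(=O)CSc2nnc(-c3cc(OC)c(OC)c(OC)c3)n2N2C(=O)c3ccccc3C2=O)cc1` has not been measured. It differs from compound 2 by (4-methoxyphenyl)carbonyl in place of hydrogen on a saturated chain carbon bound to a sulfur. Among the measured compounds shown here, no measured step speaks directly to this change: the one step recorded, a step that the two limits leave unreadable from compound 1 to compound 2, exchanges ethynyl for hydrogen at the same position and its size is hidden by the two limits. With both measured compounds at the limit, no direction beyond the scatter can be drawn, and the expected step of an at least 2.0-fold lower number from compound 2 to compound 3 (0.30 log units; that floor lies within the scatter) is set near zero with wide uncertainty. Compound 3 is estimated at 100000 nM, within a range from 20000 nM to 300000 nM, with a substantial chance that only a limit is again recorded.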

Compound 3, half-maximal inhibitory concentration: 30000 nM
Compound 3: the middle estimate sits 3.3-fold (0.52 log units) above what was measured; low and high end bracket the measured number.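

In this assay, the saturated chain carbon bound to a sulfur proves to be a place where a substituent can change the read-out: (4-methoxyphenyl)carbonyl in place of hydrogen gives an at least 6.6-fold lower number from compound 2 to compound 3 (0.82 log units; beyond the scatter), and the same group in place of ethynyl gives an at least 6.6-fold lower number from compound 1 to compound 3 (0.82 log units; beyond the scatter). On these data alone, both steps lie beyond the scatter, but each starts from a limit, so they fix only a minimum size and the full size of the change stays unknown. The earlier pair showed nothing of this, as its own step cannot be read, and compound 3 is the only one of the three that yields a number rather than a limit: the limit of > 200000 nM in this assay, at which 2 of the 3 values shown sit.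

The compounds shown do not tell whether the carbonyl, the aromatic ring or the methoxy group carries the change, since all three enter together, and a plain benzyl group or an unsubstituted phenyl ketone on the same carbon would be needed to separate them. They also leave open how a longer chain bound to the sulfur, or an amine or a carboxylic acid in place of the methoxy group, would read in this assay.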